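From a Hydroxy Group to a Pyridinyl Ring on One Core

This account rests on a few compounds, and the source may have more. Where it says the series, first, only, none or still open, it means among the compounds named here.

Compound 1, `CC1CN(CCn2ccc3ccc(Br)cc32)CCN1`, gives 52%.
Compound 2, `CN1CCCN(CCn2ccc3c(Br)cccc32)CC1`, gives 33%.
Compound 3, `CN1CCCN(CCn2ccc3ccc(O)cc32)CC1`, gives 28%.

These three numbers come from an assay on HEK293 cells for binding affinity to 5-hydroxytryptamine receptor 7 (Homo sapiens), read by radioligand binding, tested at 1 uM; on this read-out lower numbers stand for less inhibition and higher numbers for more inhibition at the one concentration tested (going by the name of the read-out). The smallest of them belongs to compound 3, yet its value and that of compound 2 sit within the usual scatter of each other, so the two cannot be told apart on this evidence. Compound 1 stands clearly beyond that scatter, and its number is the furthest from compound 3.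

The next compound, compound 4, `CN1CCCN(CCn2ccc3ccc(-c4cccnc4)cc32)CC1`, keeps the core of compound 3 and alters one group: pyridin-3-yl in place of hydroxy on an aromatic carbon. Among the compounds with values here, no pair among the measured compounds shows this kind of change, so nothing measured tells how large the effect should be or in which direction it runs. With a bigger aromatic group in place of a small hydroxy, a modest rise is expected, though the range must stay wide.

For compound 4 in this assay the estimate is 45%, spanning from 20% to 70%, which means an expected step of a number 17 percentage points higher from compound 3 to compound 4 (beyond the scatter).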

Compound 4, a percentage reported as inhibition, at one concentration (the size of the read-out at that concentration, not a potency): 35%
For compound 4 the middle estimate is 10 percentage points above the measured one; measured number inside the range.
By their numbers in this assay, from the lowest: compounds 3, 2 and 4 (each within the scatter of the next); then compound 1.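

In this assay, putting pyridin-3-yl in place of hydroxy on this aromatic carbon gives a number 7 percentage points higher from compound 3 to compound 4 (within the scatter), so this pair does not show that the swap matters for the reading. Within the data shown here, this is the first pair that differs in one place, and it shows that an added six-membered aromatic ring and the loss of the hydrogen-bond donor of hydroxy, taken together, leave the two readings indistinguishable at the one concentration tested. Nothing at hand bears on why the two compounds read alike.

On these data alone, the two changes arrive together in this single swap, so their separate contributions remain unknown, and they could either offset each other or both have little effect. As far as these compounds go, whether other groups on the same aromatic carbon, such as an amine, a carboxylic acid, a methoxy group or a phenyl ring with no ring nitrogen, would move the number beyond the usual scatter remains open, as does the question of whether a reading at one concentration would hold up as a true difference in potency.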